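A few compounds are considered here, and "the series" means these few. Any claim that something is new, unique, unknown or untested is made for them only; others in the source may bear on it.

Compound 1: `CCOC(=O)Nc1cccc2c1CN(C)CC2c1ccc(Cl)cc1`, 4.8 mg/kg.
Compound 2: `CCCCOC(=O)Nc1cccc2c1CN(C)CC2c1ccccc1`, 4 mg/kg.

Both compounds share one core and were tested in a functional assay on the whole organism for inhibition, with Mus musculus as the target; a higher number here means that more compound is needed for the effect, a lower number that less compound is needed. In this assay compound 1 gives 4.8 mg/kg, and compound 2 gives 4 mg/kg. Compound 2 shows the lowest of the two numbers, but its nearest neighbour is compound 1, and the gap between the two lies within the usual scatter of repeated measurements, so the two cannot be told apart on these data.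

The next compound, compound 3, is `CC(C)NCCC(=O)Nc1cccc2c1CN(C)CC2c1ccccc1`. It is derived from compound 2 by one change: 2-(isopropylamino)ethyl in place of butoxy on a carbonyl carbon. Within the data shown here, nothing among the measured compounds shows what such a change does, since no pair of measured compounds differs in this one place alone.

Given that, the expectation for the step from compound 2 to compound 3 in this assay is a modest rise in the dose needed, estimated as a 2.0-fold higher number from compound 2 to compound 3 (0.30 log units; within the scatter), though a result within the scatter would not be surprising. Compound 3 is therefore estimated to give 8 mg/kg, with a range from 2.5 mg/kg to 25 mg/kg.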

Compound 3, dose for half-maximal effect: 150 mg/kg
Estimate against measurement, compound 3: 19-fold (1.27 log units) below; measured number outside the range, above it.
By their numbers in this assay, from the lowest: compounds 2 and 1 (each within the scatter of the next); then compound 3.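

This place on the carbonyl carbon is far from indifferent: in this assay, 2-(isopropylamino)ethyl in place of butoxy gives a 38-fold higher number from compound 2 to compound 3 (1.57 log units; beyond the scatter), a large step beyond the scatter, so much more compound is needed for the effect. Among these compounds, until this result, no two compounds differed in this one place alone, so how much a change here could matter was unknown. The swap also alters several things at once, as an oxygen leaves, a nitrogen enters and a hydrogen-bond donor is gained, and no measurement at hand explains the size of this step.

From the compounds shown here alone, what remains open is which part of the change carries the step: a plain pentyl chain on the same carbonyl carbon would remove the oxygen without adding an amine, while 2-(isopropylamino)ethoxy would add the amine and keep the oxygen. Going by these compounds, it is also open whether any amine here behaves in this way, for instance a dimethylamino group or a shorter aminomethyl chain, or whether the effect is specific to 2-(isopropylamino)ethyl.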